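The source may hold more compounds than are shown below. What is called first, only, known or untested is meant among the compounds shown, and "the series" means these compounds.

Measured so far in a functional assay for inhibition of Polyunsaturated fatty acid 5-lipoxygenase (Homo sapiens); on this read-out lower numbers stand for stronger inhibition and higher numbers for weaker inhibition: compound 1 `O=C(O)/C(CSCCO)=N/OC(c1ccc(OCc2ccc3ccccc3n2)cc1)C1CCCCC1` gives 181 nM; compound 2 `O=C(O)/C=N/OC(c1ccc(OCc2ccc3ccccc3n2)cc1)C1CCCCCC1` gives 18 nM; compound 3 `C/C(=N\OCc1ccc(OCc2ccc3ccccc3n2)cc1)C(=O)O` gives 1400 nM.

Among these three numbers compound 1 stands second highest: compound 3 sits well above it and compound 2 well below it, both gaps beyond the scatter. Compound 4 `O=C(O)/C=N/OCC(c1ccc(OCc2ccc3ccccc3n2)cc1)C1CCCCC1` has not yet been tested in this assay. Compared with compound 1 the change is a group of 7 heavy atoms (3 carbon, 1 nitrogen, 3 oxygen; no ring) in place of a group of 11 heavy atoms (5 carbon, 1 nitrogen, 4 oxygen, 1 sulfur; no ring), on a saturated chain carbon bound to an aromatic carbon and a saturated ring carbon. Within the data shown here, no measured pair shows this step directly, so its size can only be guessed. Compound 2 carries the same plain oxime acid, and in this assay compound 2 gives 18 nM, which points towards a lower number for compound 4. The estimate for compound 4 is 60 nM, within 15 nM to 250 nM, an expected step of a 3.0-fold lower number from compound 1 to compound 4 (0.48 log units; beyond the scatter).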

Compound 4, half-maximal inhibitory concentration: 47 nM
Beside the measured number, compound 4's estimate is 1.3-fold (0.11 log units) above it; the range from low to high includes it.
By their numbers in this assay, from the lowest: compound 2; then compound 4; then compound 1; then compound 3.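

In this assay, among these compounds, the group of 7 heavy atoms in place of the group of 11 heavy atoms gives a 3.9-fold lower number from compound 1 to compound 4 (0.59 log units; beyond the scatter) and is the first step measured at this place, on a saturated chain carbon bound to an aromatic carbon and a saturated ring carbon. The larger, sulfur-bearing group is therefore not needed for a low number here. No measurement shown gives a reason for this step. Among the compounds shown here, whether the gain comes from losing the sulfur or from the shorter group stays open, since only one pair shows this change. Going by these compounds, how an amine or a longer chain would behave at this place also remains open.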